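Dichlorophenyl Swap on a Quinazolinyloxy Dienone Series

The compounds below may be only part of what the source reports. "The series", "measured", "known", "first", "only" and "open" are said of these compounds alone.

Measured in a functional assay on PC-3 cells (Homo sapiens) for inhibition, read by MTT assay, with a stated time of 72 h, tested at 10 uM; on this read-out higher numbers stand for more inhibition of growth at the one concentration tested and lower numbers for less inhibition of growth:
Compound 1, `O=C(/C=C/c1ccc(Cl)c(Cl)c1)/C=C/c1ccccc1Oc1ncnc2ccc(Cl)cc12`: 42.2%
Compound 2, `O=C(/C=C/c1ccc(Oc2ncnc3ccc(Cl)cc23)cc1)/C=C/c1ccc(Cl)c(Cl)c1`: 33.5%
Compound 3, `O=C(/C=C/c1ccc(Oc2ncnc3ccc(Cl)cc23)cc1)/C=C/c1cccc(Cl)c1Cl`: 67.4%

Compound 1 and compound 2 share the same atoms joined differently; the difference between their two cores is not broken down here. Their values lie within the scatter of each other. Compound 3 differs from compound 2 by 2,3-dichlorophenyl in place of 3,4-dichlorophenyl on a double-bonded chain carbon bound to a double-bonded chain carbon, and that change made the step of a number 33.9 percentage points higher from compound 2 to compound 3 (beyond the scatter).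

Compound 4, `O=C(/C=C/c1ccccc1Oc1ncnc2ccc(Cl)cc12)/C=C/c1cccc(Cl)c1Cl`, is not yet measured. It differs from compound 1 by 2,3-dichlorophenyl in place of 3,4-dichlorophenyl on a double-bonded chain carbon bound to a double-bonded chain carbon, the same change as from compound 2 to compound 3, at the same place. Resting on the single earlier step of a number 33.9 percentage points higher from compound 2 to compound 3 (beyond the scatter), a step of similar direction is expected for compound 4, though only one example supports it, so the expected step of a number 25.8 percentage points higher from compound 1 to compound 4 (beyond the scatter) is given with wide bounds. Compound 4 is estimated at 68%, between 45% and 88%.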

Compound 4, percent growth inhibition at one concentration: 73.8%
For compound 4 the middle estimate is 5.8 percentage points below the measured one, within the range that was stated.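

In this assay, 2,3-dichlorophenyl in place of 3,4-dichlorophenyl gave a number 31.6 percentage points higher from compound 1 to compound 4 (beyond the scatter). Set beside the earlier step, the change carried from one core to the other with its size preserved: the same change on two cores in this assay, a number 33.9 percentage points higher (beyond the scatter) from compound 2 to compound 3 and a number 31.6 percentage points higher (beyond the scatter) from compound 1 to compound 4, 2.3 percentage points apart, within the scatter of two such steps This rests on only two cores in a single cell line at a single concentration, so it does not show that the step would hold on any other core, and it does not explain why the change raises the number.

The compounds shown leave open what a phenyl ring bearing methoxy or trifluoromethyl in place of the two chlorines would give. They also leave open whether compound 3 and compound 4 would keep their lead over compound 2 and compound 1 across a range of concentrations.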